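Fluoro to trifluoromethyl on two cores: cytotoxicity notes

The compounds below may be only part of what the source reports. "The series", "measured", "known", "first", "only" and "open" are said of these compounds alone.

Compound 1 `CC(=O)Nc1ccc(O)c(C(=O)/C=C/c2cccc(F)c2)c1` and compound 2 `CC(=O)Nc1ccc(O)c(C(=O)/C=C/c2cccc(C(F)(F)F)c2)c1` share one core; compound 3 `COc1c(-c2cccc(F)c2)oc2ccc(N)cc2c1=O` and compound 4 `COc1c(-c2cccc(C(F)(F)F)c2)oc2ccc(N)cc2c1=O` share another. How the two cores differ is not broken down here. In an ADME assay on MT4 cells (Homo sapiens) for cytotoxicity, read by MTT assay, with a stated time of 4 days (on this read-out lower numbers stand for higher toxicity in this test and higher numbers for lower toxicity in this test), compound 1 gives 30100 nM, and compound 2 gives 32100 nM. The change between them is trifluoromethyl in place of fluoro on an aromatic carbon, and it made a 1.1-fold higher number from compound 1 to compound 2 (0.03 log units; within the scatter). In this assay compound 3 gives 113000 nM, the highest number among the three measured compounds. Compound 4 carries the same change on the second core: trifluoromethyl in place of fluoro on an aromatic carbon. Because the same change made a 1.1-fold higher number from compound 1 to compound 2 (0.03 log units; within the scatter) on the first core, the expected step on compound 4 is a 1.1-fold higher number from compound 3 to compound 4 (0.03 log units; within the scatter). Compound 4 is therefore estimated at 120000 nM in this assay, with an expected range from 55000 nM to 260000 nM.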

Compound 4, half-maximal cytotoxic concentration: 73100 nM
Compound 4: middle estimate off by 1.6-fold (0.22 log units), on the high side; the measured number falls inside the stated range.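

In this assay, trifluoromethyl in place of fluoro on the second core gives a 1.5-fold lower number from compound 3 to compound 4 (0.19 log units; within the scatter), so neither core shows a step that stands clear of repeat measurement. As far as this read-out can tell, the change carries from one core to the other: the same change on two cores in this assay, a 1.1-fold higher number (0.03 log units; within the scatter) from compound 1 to compound 2 and a 1.5-fold lower number (0.19 log units; within the scatter) from compound 3 to compound 4, 1.6-fold (0.22 log units) apart, within the scatter of two such steps. This rests on one pair per core, with both steps inside the scatter, so it does not show that a larger step would carry over or how the change would behave on a further core.

Open, going by these compounds, is whether chloro, a nitrile or a carboxylic acid in place of fluoro would also leave this assay within the scatter on these cores. The same question stands for trifluoromethyl at another place on that ring.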